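Quinolin-3-yl replaces 1H-indol-5-yl on an amine nitrogen

The source may hold more compounds than are shown below. What is called first, only, known or untested is meant among the compounds shown, and "the series" means these compounds.

Compound 1 `O=C(/C=C\Nc1cnc2ccccc2c1)c1c(-c2ccccc2)nc2ccccn12` gives 1750 nM
Compound 2 `O=C(/C=C\Nc1ccc2[nH]ccc2c1)c1c(-c2ccc(Cl)cc2)nc2ccccn12` gives 1010 nM

Within the data shown here, in a functional assay on A549 cells (Homo sapiens) for cytotoxicity, read by MTT assay, with a stated time of 48 h (on this read-out higher numbers stand for weaker inhibition and lower numbers for stronger inhibition), compound 2 gives 1010 nM and so stands within the usual scatter of compound 1, the only other compound measured. Compound 3 `O=C(/C=C\Nc1cnc2ccccc2c1)c1c(-c2ccc(Cl)cc2)nc2ccccn12` differs from compound 2 by one change (quinolin-3-yl in place of 1H-indol-5-yl on an amine nitrogen), with quinolin-3-yl in place of 1H-indol-5-yl on an amine nitrogen. Among the measured compounds shown here, no measured step shows this change alone. Compound 1 also carries quinolin-3-yl and gives 1750 nM, so no shift beyond the scatter is expected. The expected step is a 1.2-fold higher number from compound 2 to compound 3 (0.07 log units; within the scatter) and has no firm direction. Compound 3 is estimated at 1200 nM, with an expected range of 450 nM to 3000 nM.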

Compound 3, half-maximal inhibitory concentration: 2880 nM
The estimate for compound 3 lay 2.4-fold (0.38 log units) below the measured number; the measured number falls inside the stated range.
By their numbers in this assay, from the lowest: compounds 2, 1 and 3 (each within the scatter of the next, the first and the last beyond it).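

In this assay, with the chloro group kept, the amine nitrogen proves sensitive to this swap: quinolin-3-yl in place of 1H-indol-5-yl gives a 2.9-fold higher number from compound 2 to compound 3 (0.46 log units; beyond the scatter) and this modest step lies beyond the scatter. With quinolin-3-yl kept, chloro in place of hydrogen on an aromatic carbon gives a 1.6-fold higher number from compound 1 to compound 3 (0.22 log units; within the scatter) and this stays within the scatter. No measurement shown accounts for the step at the amine nitrogen. Open, as far as these compounds go, is where a plain phenyl or a pyridin-3-yl on that nitrogen would fall, and whether the chloro change reads the same with 1H-indol-5-yl there.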